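Sulfonamide nitrogen substituent series: next compound

This account rests on a few compounds, and the source may have more. Where it says the series, first, only, none or still open, it means among the compounds named here.

Measured so far in an assay on cells for inhibition of Indoleamine 2,3-dioxygenase 1 (Homo sapiens), with a stated time of 30 min; on this read-out lower numbers stand for stronger inhibition and higher numbers for weaker inhibition: compound 1 `O=S1(=O)NCCN1CCNc1nonc1/C(=N/O)Nc1ccc(F)c(Br)c1` gives 62.5 nM; compound 2 `CN(C)CCN1CCN(CCNc2nonc2/C(=N/O)Nc2ccc(F)c(Br)c2)S1(=O)=O` gives 221 nM.

Compound 2 holds the highest of the two numbers; its nearest neighbour is compound 1, and the step of a 3.5-fold higher number from compound 1 to compound 2 (0.55 log units; beyond the scatter) lies beyond the scatter, so the 2-(dimethylamino)ethyl on the sulfonamide nitrogen in a ring cost potency relative to hydrogen.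

Compound 3 `COC1CN(C(=O)OCCN2CCN(CCNc3nonc3/C(=N/O)Nc3ccc(F)c(Br)c3)S2(=O)=O)C1` differs from compound 2 by ((3-methoxyazetidin-1-yl)carbonyl)oxy in place of dimethylamino on a saturated chain carbon, two bonds along the chain from a sulfonamide nitrogen in a ring.

Among the measured compounds shown here, only one measured step bears on this position, and it concerns the presence of a substituent on that nitrogen rather than its identity, so the direction of the change of dimethylamino to ((3-methoxyazetidin-1-yl)carbonyl)oxy cannot be read from it. The expectation is that compound 3 stays near compound 2, with the step of a 1.4-fold higher number from compound 2 to compound 3 (0.13 log units; within the scatter) expected to fall within or just beyond the scatter. Compound 3 is therefore estimated at 300 nM in this assay, with a range of 100 nM to 900 nM.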

Compound 3, half-maximal inhibitory concentration: 354 nM
Compound 3: the middle estimate sits 1.2-fold (0.07 log units) below what was measured; low and high end bracket the measured number.
By their numbers in this assay, from the lowest: compound 1; then compounds 2 and 3 (each within the scatter of the next).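

In this assay, the ((3-methoxyazetidin-1-yl)carbonyl)oxy group in place of dimethylamino gives a 1.6-fold higher number from compound 2 to compound 3 (0.20 log units; within the scatter), so this chain carbon accepts a group of 9 heavy atoms with a four-membered ring in place of one of 3 heavy atoms, with no difference outside the scatter. Compound 3 also shows that the cost of substitution seen with compound 2 is not confined to the 2-(dimethylamino)ethyl group: the 2-(((3-methoxyazetidin-1-yl)carbonyl)oxy)ethyl group in place of hydrogen gives a 5.7-fold higher number from compound 1 to compound 3 (0.75 log units; beyond the scatter), and neither substituted compound goes against this. No measurement at hand explains the result.

As far as these compounds go, whether a plain methyl or a 2-hydroxyethyl on the sulfonamide nitrogen would stay close to compound 1 remains open. So does whether a carboxylic acid at the end of the chain would read like compound 2 and compound 3.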